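The source may report more compounds than this note shows. Statements on the series, on what has been measured and on what is new or still open speak of the compounds shown alone.

Working notes on the series. Three compounds sharing one core have numbers in a functional assay on CCRF-CEM cells for antagonist activity at C-X-C chemokine receptor type 4 (Homo sapiens), read by calcium flux, with stated times of 25 min and 90 s; a higher number here means a weaker inhibitor, a lower number a stronger inhibitor. Compound 1 `C/C(CN(C[C@H]1Cc2ccccc2CN1)[C@H]1CCCc2cccnc21)=C(/F)CN` gives 1800 nM; compound 2 `C/C(CN)=C(\F)CN(C[C@H]1Cc2ccccc2CN1)[C@H]1CCCc2cccnc21` gives 28 nM; compound 3 `NC[C@H]1CC[C@H](CN(C[C@H]2Cc3ccccc3CN2)[C@H]2CCCc3cccnc32)CC1` gives 340 nM. Compound 3 thus stands second highest of the three: the step of a 5.3-fold lower number from compound 1 to compound 3 (0.72 log units; beyond the scatter) is modest, the step of a 12-fold higher number from compound 2 to compound 3 (1.08 log units; beyond the scatter) is large, and both lie beyond the scatter.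

The next compound is compound 4 `NC(=O)NC/C=C\CN(C[C@H]1Cc2ccccc2CN1)[C@H]1CCCc2cccnc21`. Relative to compound 3 the change is a group of 7 heavy atoms (4 carbon, 2 nitrogen, 1 oxygen; no ring) in place of a group of 8 heavy atoms (7 carbon, 1 nitrogen; one six-membered non-aromatic ring of carbon only), on a saturated chain carbon bound to an amine nitrogen. Every measured step in the series sits on this same saturated chain carbon bound to an amine nitrogen, so all three bear on it: a 64-fold lower number from compound 1 to compound 2 (1.81 log units; beyond the scatter), a 5.3-fold lower number from compound 1 to compound 3 (0.72 log units; beyond the scatter) and a 12-fold higher number from compound 2 to compound 3 (1.08 log units; beyond the scatter). They show that swapping the group at this position moves the number by modest to large amounts in either direction. Within the data shown here, no measured compound carries a group without a primary amine, and the entering group has none, so the direction rests on that absence alone. Compound 4 is therefore expected to give a higher number in this assay, with a step of a 5.9-fold higher number from compound 3 to compound 4 (0.77 log units; beyond the scatter) anticipated. The estimate for compound 4 is 2000 nM, with a range from 400 nM to 10000 nM.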

Compound 4, half-maximal inhibitory concentration: 210 nM
The estimate for compound 4 lay 9.5-fold (0.98 log units) above the measured number; measured number outside the range, below it.
By their numbers in this assay, from the lowest: compound 2; then compounds 4 and 3 (each within the scatter of the next); then compound 1.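

In this assay, the position on a saturated chain carbon bound to an amine nitrogen keeps a number in the same range without a primary amine: a 1.6-fold lower number from compound 3 to compound 4 (0.21 log units; within the scatter) lies within the scatter, so the open-chain group of compound 4 cannot be told apart from 4-(aminomethyl)cyclohexyl here. Compound 4 also falls inside the span of the two fluorine-bearing groups, as shown by an 8.6-fold lower number from compound 1 to compound 4 (0.93 log units; beyond the scatter) and by a 7.5-fold higher number from compound 2 to compound 4 (0.88 log units; beyond the scatter) as well. A primary amine alone therefore does not order the series, since compound 1 and compound 2 both carry one and lie on opposite sides of compound 4, and nothing available accounts for these differences.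

The compounds shown leave open whether the carbonyl-bearing end of the group in compound 4 contributes anything, which a plain butenyl chain or a primary amine on the same unfluorinated chain would test directly. Also open is how a carboxylic acid at this position would compare, as no group of that kind appears among these compounds.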